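The source may report more compounds than this note shows. Statements on the series, on what has been measured and on what is new or still open speak of the compounds shown alone.

Compound 2 `CN(C)CCn1cnnc1-c1cc(Oc2ccc(NC(=O)N/N=C/c3ccc(F)cc3)cc2F)ccn1` carries a 4-fluorophenyl on the carbon with a double bond to nitrogen, and in a functional assay on MKN-45 cells (Homo sapiens) for cytotoxicity, read by MTT assay, with a stated time of 72 h (a lower number here means a stronger inhibitor, a higher number a weaker inhibitor), compound 2 gives 1030 nM, the higher of the two numbers measured in this series. Compound 3 `CN(C)CCn1cnnc1-c1cc(Oc2ccc(NC(=O)N/N=C/c3cccc(Br)c3)cc2F)ccn1`, which puts a 3-bromophenyl on that carbon, gives 450 nM in this assay, a 2.3-fold lower number from compound 2 to compound 3 (0.36 log units; beyond the scatter). Compound 1 `Cn1ncnc1-c1cc(Oc2ccc(NC(=O)N/N=C/c3ccccc3)cc2F)ccn1` reaches only a limit in this assay, > 100000 nM (the limit of > 100000 nM in this assay, at which 1 of the 3 values shown sits).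

Compound 4 `Cc1cc(/C=N/NC(=O)Nc2ccc(Oc3ccnc(-c4nncn4CCN(C)C)c3)c(F)c2)cc(C)c1O` differs from compound 2 in one place: 4-hydroxy-3,5-dimethylphenyl in place of 4-fluorophenyl on a carbon with a double bond to nitrogen. For the measured compounds named here, the only measured step that touches the same carbon is the one from compound 2 to compound 3, and it was modest. Going by the values given here, no measured compound carries a hydroxyl-bearing ring at this position, so the direction of the step is uncertain. The move from compound 2 to compound 4 is therefore expected to be small, a 1.5-fold lower number from compound 2 to compound 4 (0.17 log units; within the scatter), and compound 4 is estimated to give 700 nM in this assay, within a range of 200 nM to 2500 nM.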

Compound 4, half-maximal inhibitory concentration: 1510 nM
Estimate against measurement, compound 4: 2.2-fold (0.33 log units) below; low and high end bracket the measured number.
By their numbers in this assay, from the lowest: compound 3; then compounds 2 and 4 (each within the scatter of the next). At a limit, above all of these: compound 1.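

In this assay, the carbon with a double bond to nitrogen takes 4-hydroxy-3,5-dimethylphenyl, the first ring here with a hydrogen-bond donor, with no change beyond the scatter against 4-fluorophenyl: a 1.5-fold higher number from compound 2 to compound 4 (0.17 log units; within the scatter). The same group does stand apart from 3-bromophenyl, with a 3.4-fold higher number from compound 3 to compound 4 (0.53 log units; beyond the scatter). Among compounds 2, 3 and 4, which differ only at this carbon, the 3-bromophenyl of compound 3 is therefore the one ring separated from the other two, and the added hydroxyl and methyl groups of compound 4 give no gain over the fluorine of compound 2.

On these data alone, it remains open whether the lower number of compound 3 follows the bromine itself or its place on the ring, and what an amine or a carboxylic acid on this ring would give. Nothing given here accounts for the differences among these rings.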